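Swapping the heteroaryl group on the ring amine nitrogen

The source may hold more compounds than are shown below. What is called first, only, known or untested is meant among the compounds shown, and "the series" means these compounds.

Measured compounds:
Compound 1, `C[C@H]1CC[C@@H](c2nc3cccc(Cl)c3c(=O)n2N2CCOCC2)N1c1nc(N)nc2[nH]cnc12`, in a functional assay on SU-DHL-6 cells (Homo sapiens) for inhibition, read by MTT assay, with a stated time of 72 h (on this read-out higher numbers stand for weaker inhibition and lower numbers for stronger inhibition), gives 420 nM.
Compound 2, `N#Cc1c(N)nc(N)nc1N1[C@H](c2nc3cccc(Cl)c3c(=O)n2N2CCOCC2)C[C@@H]2CCCC[C@@H]21`, in this assay gives 1340 nM.

Of the two numbers, compound 1 holds the lower one; compound 2 stands at a higher number, and the gap between them lies beyond the usual scatter. Compound 3, `C[C@H]1CC[C@@H](c2nc3cccc(Cl)c3c(=O)n2N2CCOCC2)N1c1nc(N)nc(N)c1C#N`, has not been measured in this assay. It is built from compound 1 by one change: a group of 10 heavy atoms (5 carbon, 5 nitrogen; one six-membered aromatic ring with 2 hetero atoms) in place of a group of 10 heavy atoms (5 carbon, 5 nitrogen; one five-membered aromatic ring with 2 hetero atoms, one six-membered aromatic ring with 2 hetero atoms), on an amine nitrogen in a ring. The same atoms remain, joined differently, so the group that enters carries a nitrile and one ring fewer than the group that leaves. Among the compounds with values here, no measured pair shows this exact exchange on the shared core, so the step can only be guessed. A modest loss is expected, the step from compound 1 to compound 3 being estimated as a 1.7-fold higher number from compound 1 to compound 3 (0.22 log units; within the scatter). Compound 3 is therefore expected to give about 700 nM, within a range from 250 nM to 2500 nM.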

Compound 3, half-maximal inhibitory concentration: 310 nM
For compound 3 the middle estimate is 2.3-fold (0.35 log units) above the measured one; the measured number falls inside the stated range.
By their numbers in this assay, from the lowest: compounds 3 and 1 (each within the scatter of the next); then compound 2.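

In this assay, placing 2,6-diamino-5-cyanopyrimidin-4-yl on the amine nitrogen in the ring, where compound 1 carries a group with a five-membered and a six-membered aromatic ring, gives a 1.4-fold lower number from compound 1 to compound 3 (0.13 log units; within the scatter). This amine nitrogen therefore accepts a group with one aromatic ring and a nitrile as readily as the group with two aromatic rings, and the two groups cannot be told apart here, something the earlier pair could not show, as compound 1 and compound 2 differ in more than one place. Nothing measured here accounts for this result.

Going by these compounds, it remains open what a carboxamide or a chlorine in place of the nitrile would give on this group. Also open, on these data alone, is whether an ethyl group could replace the methyl group that compound 1 and compound 3 share.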